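Tert-butylphenyl Replacing Dimethylbenzyl on the Quinoline Core

The source may hold more compounds than are shown below. What is called first, only, known or untested is meant among the compounds shown, and "the series" means these compounds.

Measured compounds:
compound 1 `COc1cccc(CNCCCNc2ccnc3cc(-c4cccc5ccccc45)ccc23)c1O` 2520 nM
compound 2 `COc1ccc(F)cc1CNCCCNc1ccnc2cc(-c3ccc(C(C)(C)C)cc3)ccc12` 620 nM
compound 3 `COc1cccc(CNCCCNc2ccnc3cc(Cc4cc(C)cc(C)c4)ccc23)c1O` 2680 nM

In an ADME assay on HepG2 cells (Homo sapiens) for cytotoxicity, read by luminescence, CellTiter-Glo and ATP content, with a stated time of 72 h (on this read-out higher numbers stand for an effect only at larger amounts of compound and lower numbers for an effect already at smaller amounts), compound 3 gives 2680 nM, the highest of the three numbers. Its nearest neighbour is compound 1, and the step of a 1.1-fold higher number from compound 1 to compound 3 (0.03 log units; within the scatter) lies within the scatter. Compound 2 gives 620 nM, well apart from compound 3.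

Compound 4 `COc1cccc(CNCCCNc2ccnc3cc(-c4ccc(C(C)(C)C)cc4)ccc23)c1O` has not yet been measured. It differs from compound 3 by 4-(tert-butyl)phenyl in place of 3,5-dimethylbenzyl on an aromatic carbon. For the measured compounds named here, no measured step follows exactly this change. Compound 2 carries the same entering group but differs from compound 4 in more than one place, so its value is only a loose guide. A step of a 2.2-fold lower number from compound 3 to compound 4 (0.35 log units; beyond the scatter) is therefore expected, pointing toward the number of compound 2, with little confidence in its size.

The estimate for compound 4 in this assay is 1200 nM, within 450 nM to 3200 nM.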

Compound 4, half-maximal effective concentration: 690 nM
Compound 4: middle estimate off by 1.7-fold (0.24 log units), on the high side, within the range that was stated.
By their numbers in this assay, from the lowest: compounds 2 and 4 (each within the scatter of the next); then compounds 1 and 3 (each within the scatter of the next).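

In this assay, 4-(tert-butyl)phenyl on this aromatic carbon separates from both earlier groups, with a 3.9-fold lower number from compound 3 to compound 4 (0.59 log units; beyond the scatter) and a 3.7-fold lower number from compound 1 to compound 4 (0.56 log units; beyond the scatter), whereas those two earlier groups had stayed within the scatter of each other. On the saturated chain carbon bound to an amine nitrogen, 2-hydroxy-3-methoxyphenyl in place of 5-fluoro-2-methoxyphenyl gives a 1.1-fold higher number from compound 2 to compound 4 (0.05 log units; within the scatter), so that exchange separates nothing here. No evidence accompanies these steps to account for them. The compounds shown leave open how a 4-carboxyphenyl or a 4-(dimethylamino)phenyl group on this carbon would read.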